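Swapping a Cyclohexyl Ring for a Fluorinated Phenyl Ring

This account rests on a few compounds, and the source may have more. Where it says the series, first, only, none or still open, it means among the compounds named here.

Measured so far:
- compound 1, `O=C(/C(=C/c1ccc(Cl)cc1Cl)CCl)c1ccccc1`, in a functional assay on HBL-100 cells (Homo sapiens) for inhibition, read by sulforhodamine B assay, with a stated time of 48 h (on this read-out higher numbers stand for weaker inhibition of growth and lower numbers for stronger inhibition of growth), gives 3100 nM
- compound 2, `CC(=O)OC/C(=C\C1CCCCC1)C(=O)c1ccccc1`, in this assay gives 21000 nM

Compound 2 stands at the highest of the two numbers shown, that is, it is the weaker inhibitor of the pair. Its nearest neighbour is compound 1, which gives a lower number, and that gap lies beyond the scatter of repeated measurements. Among the compounds with values here, the two compounds differ in more than one place, so no single step between them can be read from the numbers; what they show is only that compound 1 inhibits growth more strongly than compound 2.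

Compound 3, `CC(=O)OC/C(=C\c1ccccc1F)C(=O)c1ccccc1`, has not yet been measured. It differs from compound 2 in one place: 2-fluorophenyl in place of cyclohexyl on a double-bonded chain carbon bound to a double-bonded chain carbon. Within the data shown here, the only guidance here is that compound 1, the stronger inhibitor, carries an aromatic ring at the same position of the chain, while compound 2 carries the saturated cyclohexyl ring. On that slender basis a modest move toward stronger inhibition is expected, of the size a 2.3-fold lower number from compound 2 to compound 3 (0.37 log units; beyond the scatter) in this assay. For compound 3 the expected value is therefore 9000 nM, with a range from 3000 nM to 30000 nM.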

Compound 3, concentration for 50% growth inhibition: 17000 nM
For compound 3 the middle estimate is 1.9-fold (0.28 log units) below the measured one, and the stated range covers the measured number.
By their numbers in this assay, from the lowest: compound 1; then compounds 3 and 2 (each within the scatter of the next).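

In this assay, within the data shown here, putting 2-fluorophenyl in place of cyclohexyl on a double-bonded chain carbon bound to a double-bonded chain carbon gives a 1.2-fold lower number from compound 2 to compound 3 (0.09 log units; within the scatter), the first step at this position that can be read, and it lies within the scatter. For this pair, then, a saturated carbon ring and a fluorine-bearing aromatic ring at this position give numbers that cannot be told apart, so this swap of rings, taken as a whole, does not move growth inhibition beyond the scatter. No measurement at hand offers a reason for this result.

Compound 1 differs from both compound 2 and compound 3 in more than one place, so its gap to either cannot be assigned to the ring or to the chloromethyl group that it carries instead of the acetoxymethyl group. Also open, as far as these compounds go, is how a plain phenyl ring would compare, which would separate the aromatic ring from its fluorine, and whether an amine on that ring or a longer chain in its place would shift the number beyond the scatter.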